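The compounds below may be only part of what the source reports. "The series", "measured", "known", "first", "only" and "open" are said of these compounds alone.

Measured so far in a functional assay on A549 cells (Homo sapiens) for antiproliferative activity, read by CCK-8 assay, with a stated time of 72 h; on this read-out higher numbers stand for weaker inhibition and lower numbers for stronger inhibition:
- compound 1 `Nc1ccccc1NC(=O)c1ccc(COc2ccc(Br)cc2)cc1` gives 24400 nM
- compound 2 `CCc1ccc(OCc2ccc(C(=O)Nc3ccccc3N)cc2)cc1` gives 6420 nM
- compound 3 `CC(C)c1ccc(OCc2ccc(C(=O)Nc3ccccc3N)cc2)cc1` gives 7460 nM

Compound 3 (7460 nM) stands with compound 2 within the scatter, and both lie under compound 1. The next step leads to compound 4 `Nc1ccccc1NC(=O)c1ccc(COc2ccc(F)cc2)cc1` by the change fluoro in place of isopropyl on an aromatic carbon and puts fluoro in place of isopropyl on an aromatic carbon, para to a large group.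

Among the measured compounds shown here, three measured steps bear on it. The closest is a 3.3-fold lower number from compound 1 to compound 3 (0.51 log units; beyond the scatter) with isopropyl in place of bromo, and a 3.8-fold lower number from compound 1 to compound 2 (0.58 log units; beyond the scatter) with ethyl in place of bromo runs the same way. Read backwards, these two put the one halogen compound on the higher side of the two alkyl compounds by a modest margin. The step of a 1.2-fold higher number from compound 2 to compound 3 (0.07 log units; within the scatter) shows no separation between ethyl and isopropyl. For the measured compounds named here, no fluoro compound has been measured, and fluoro need not follow bromo, so a modest move to a higher number in this assay is expected, probably smaller than the gap seen with bromo. The expected step is a 1.6-fold higher number from compound 3 to compound 4 (0.21 log units; within the scatter) on this reading. For compound 4 the estimated value is 12000 nM (expected range 5000 nM to 30000 nM).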

Compound 4, half-maximal inhibitory concentration: 5370 nM
Estimate against measurement, compound 4: 2.2-fold (0.35 log units) above; measured number inside the range.
By their numbers in this assay, from the lowest: compounds 4, 2 and 3 (each within the scatter of the next); then compound 1.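

Working notes on the series: in this assay, fluoro at this place, para to a large group, falls in with the alkyl groups, since a 1.4-fold lower number from compound 3 to compound 4 (0.14 log units; within the scatter) and a 1.2-fold lower number from compound 2 to compound 4 (0.08 log units; within the scatter) both lie within the scatter, and the exchange of three carbons in isopropyl for a single fluorine gives no separation here. Fluoro does not follow bromo: a 4.5-fold lower number from compound 1 to compound 4 (0.66 log units; beyond the scatter) is beyond the scatter, so the earlier gap marks compound 1 alone among these four and is no divide between halogens and alkyl groups. Nothing at hand accounts for the separate standing of compound 1.

Open, as far as these compounds go, is whether the bromo gap is peculiar to bromine, which chloro or iodo at the same place would test, and whether it belongs to a wider set of groups such as trifluoromethyl. Also open, from the compounds shown here alone, is whether this place tolerates groups of another kind, such as an amine, a carboxylic acid or a longer chain, or whether the flat run from fluoro to isopropyl ends with them.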